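The source may report more compounds than this note shows. Statements on the series, on what has been measured and on what is new or still open speak of the compounds shown alone.

Compound 1 `CNC(=O)/C=C1\CCc2cc(F)c(F)cc21` gives 100% in a functional assay on the whole organism with Mus musculus as the target, at a dose of 100 mg/kg by the intraperitoneal route; on this read-out higher numbers stand for more inhibition at the one dose given (going by the name of the read-out) and lower numbers for less inhibition.
Compound 2 `CCNC(=O)/C=C1\CCc2c(F)cc(F)cc21` gives 67%.
Compound 3 `Cc1ccc2c(c1)/C(=C/C(N)=O)CC2` gives 33%.

Among these three, compound 1 stands highest: compound 2 lies a step below it that goes beyond the usual scatter, and compound 3 lies lower still, also beyond the scatter. Compound 4 `O=C(/C=C1\CCc2cc(F)c(F)cc21)NC1CC1` has not been measured. It differs from compound 1 in a single place, (cyclopropyl in place of methyl on an amide-type nitrogen). Among the measured compounds shown here, no pair of measured compounds shows this change, so no measured step tells its size. Given that compound 1 already reaches 100%, a step of a number 15 percentage points lower from compound 1 to compound 4 (beyond the scatter) is expected, that is, at most a modest downward move and possibly none beyond the scatter. Compound 4 is therefore estimated at 85%, with a range from 55% to 100%.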

Compound 4, a percentage reported as inhibition, in the whole organism at one dose (the size of the read-out at that dose, not a potency): 50%
Beside the measured number, compound 4's estimate is 35 percentage points above it; the measured number lies below the stated range.
By their numbers in this assay, from the lowest: compound 3; then compound 4; then compound 2; then compound 1.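

In this assay, cyclopropyl in place of methyl on an amide-type nitrogen gives a number 50 percentage points lower from compound 1 to compound 4 (beyond the scatter), a large step on an otherwise unchanged core. Among the compounds shown here, this is the first direct reading of this position, and it shows that the inhibition at the one dose depends on the group carried there. Nothing measured here says why the number falls.

Open, as far as these compounds go, is how an isopropyl group or a longer chain on that nitrogen would read on the core of compound 1. Also open, from the compounds shown here alone, is whether the same change would cost as much on another core.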